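Notes on the N-aryl change from compound 2 to compound 4

This account rests on a few compounds, and the source may have more. Where it says the series, first, only, none or still open, it means among the compounds named here.

Compound 2 `COc1ccccc1N1C(=O)/C(=C/c2ccc(OCc3ccc(C(=O)O)cc3)cc2)SC1=S` gives 2000 nM in an assay on isolated protein for inhibition of Apoptosis regulator Bcl-2 (Homo sapiens), read by fluorescence polarization (on this read-out lower numbers stand for stronger inhibition and higher numbers for weaker inhibition), the lowest of the two numbers in hand. Among the compounds with values here, compound 3 `COc1ccccc1N1C(=O)/C(=C/c2ccc(OCC(=O)Nc3ccc(C(=O)O)cc3)cc2)SC1=S` gives 10000 nM in this assay, and the step of a 5.0-fold higher number from compound 2 to compound 3 (0.70 log units; beyond the scatter) is the only single-point step measured so far. Within the data shown here, compound 1 `O=C(O)c1ccc(COc2cccc(/C=C3\SC(=S)N(c4ccccc4)C3=O)c2)cc1` reports only a limit, > 10000 nM in this assay, and not a number; it is the one value sitting at the limit of > 10000 nM in this assay, at which 1 of the 3 values shown sits. Among the measured compounds shown here, compound 1 differs from compound 2 in more than one place, so no step between them is drawn.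

Compound 4 `O=C(O)c1ccc(COc2ccc(/C=C3\SC(=S)N(c4c(F)cccc4F)C3=O)cc2)cc1` differs from compound 2 in one place: 2,6-difluorophenyl in place of 2-methoxyphenyl on an amide-type nitrogen in a ring. For the measured compounds named here, no measured step touches the group on the amide-type nitrogen in the ring; the step from compound 2 to compound 3 altered the other end of the molecule and therefore says nothing about this change. With no guidance from the measured steps, the expectation for compound 4 is a step of a 1.5-fold higher number from compound 2 to compound 4 (0.18 log units; within the scatter) that stays within the scatter, with a wide range to either side. Compound 4 is therefore estimated at 3000 nM in this assay, between 800 nM and 15000 nM.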

Compound 4, inhibition constant: > 10000 nM
Compound 4: only a limit was reported; the forecaster's own chance of this, stated with the estimate: 25%; middle value at least 3.3-fold (0.52 log units) away from the limit.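

Replacing 2-methoxyphenyl with 2,6-difluorophenyl on the amide-type nitrogen in the ring gives an at least 5.0-fold higher number from compound 2 to compound 4 (0.69 log units; beyond the scatter), so in this assay this position is not indifferent to the group it carries, a point the earlier step at the other end of the molecule could not address. As far as these compounds go, compound 4 gives > 10000 nM, which is a limit and not a number, so the full size of the step remains unknown. The only numbers in hand carry 2-methoxyphenyl on this nitrogen, and the other values sit at one limit: the limit of > 10000 nM in this assay, at which 2 of the 4 values shown sit.

From the compounds shown here alone, it remains open whether the change in this assay follows from removing the methoxy group or from adding the two fluorines; a phenyl ring carrying an ethoxy group or a single fluorine on this nitrogen would help separate the two. Also open, going by these compounds, is whether the step carries over to the (4-carboxyphenyl)carbamoyl end of compound 3.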